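Ester Tail to Hydroxyl Chain at an Aromatic Nitrogen

The source may hold more compounds than are shown below. What is called first, only, known or untested is meant among the compounds shown, and "the series" means these compounds.

Measured so far in a functional assay on A549 cells (Homo sapiens) for antiproliferative activity, read by sulforhodamine B assay, with a stated time of 72 h; a higher number here means a weaker inhibitor, a lower number a stronger inhibitor:
compound 1, `COc1ncc(-c2ccc3ncnc(Nc4ccc(OCCO)cc4)c3c2)cc1NS(C)(=O)=O`: 5200 nM
compound 2, `COC(=O)Cn1cc(Nc2ncnc3ccc(-c4cnc(OC)c(NS(=O)(=O)c5ccc(F)cc5F)c4)cc23)cn1`: 4280 nM

Of the two numbers, compound 2 carries the lower one, but its gap to compound 1 lies within the usual scatter, so the two compounds cannot be told apart as inhibitors in this assay. Compound 3, `COc1ncc(-c2ccc3ncnc(Nc4cnn(CCCO)c4)c3c2)cc1NS(=O)(=O)c1ccc(F)cc1F`, has not yet been measured. It differs from compound 2 in one place: 2-hydroxyethyl in place of methoxycarbonyl on a saturated chain carbon bound to an aromatic nitrogen. Within the data shown here, no pair of measured compounds differing in a single place is available, so there is no directly comparable step to lean on. What the two measured compounds do show is that quite different groups attached to the shared core leave the read-out in the same region. Because compound 2 gives 4280 nM with a group of similar size at this position, the exchange is expected to move the number little, in no clear direction, and any shift is expected to stay within the scatter. The estimated step of a 1.1-fold lower number from compound 2 to compound 3 (0.03 log units; within the scatter) is therefore expected to be small. For compound 3 the half-maximal inhibitory concentration is estimated at 4000 nM, with a range from 1500 nM to 11000 nM.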

Compound 3, half-maximal inhibitory concentration: 4830 nM
Compound 3: the middle estimate sits 1.2-fold (0.08 log units) below what was measured; low and high end bracket the measured number.
By their numbers in this assay, from the lowest: compounds 2, 3 and 1 (each within the scatter of the next).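

Among these compounds, exchanging methoxycarbonyl for 2-hydroxyethyl on a saturated chain carbon bound to an aromatic nitrogen gives a 1.1-fold higher number from compound 2 to compound 3 (0.05 log units; within the scatter) in this assay, and this is the first comparison here of two compounds that differ in one place. Read one bond further out, the pair shows that (methoxycarbonyl)methyl and 3-hydroxypropyl cannot be told apart at this position in this assay, even though the group leaving has no hydrogen-bond donor and the group entering has one. The compounds shown offer no measurement that accounts for this result.

Whether a carboxylic acid, an amine or a longer chain at this position would also stay within the scatter of compound 2 remains open, as no such group is among the compounds shown. Among the compounds shown here, also open is whether the exchange of methoxycarbonyl for 2-hydroxyethyl would give a similar result on a different core, as this single pair is the only reading of that change here.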